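From hydroxy to fluoro in a growth inhibition series

The source may report more compounds than this note shows. Statements on the series, on what has been measured and on what is new or still open speak of the compounds shown alone.

In a functional assay on NCI/ADR-RES cells (Homo sapiens) for inhibition (on this read-out higher numbers stand for weaker inhibition of growth and lower numbers for stronger inhibition of growth), compound 3 (`COc1ccc(-n2cnnc2-c2cc(OC)c(OC)c(OC)c2)cc1O`) gives 1550 nM and so stands within the scatter of compound 1 (`COc1ccc(-n2cnnc2-c2cc(OC)c(OC)c(OC)c2)cc1`), which gives 1780 nM in the same read-out. Both lie well above compound 2 (`COc1cc(-c2nncn2-c2ccc(N(C)C)cc2)cc(OC)c1OC`), which gives 129 nM and is the only clear outlier among the three.

Compound 4 (`COc1ccc(-n2cnnc2-c2cc(OC)c(OC)c(OC)c2)cc1F`) has fluoro in place of hydroxy on an aromatic carbon, ortho to a methoxy group and meta to a large group (fluoro in place of hydroxy on an aromatic carbon). For the measured compounds named here, the closest precedent is the introduction of that hydroxy in place of hydrogen, which gave a 1.1-fold lower number from compound 1 to compound 3 (0.06 log units; within the scatter) and left the number unmoved at this carbon. The dimethylamino in place of methoxy gave the large 14-fold lower number from compound 1 to compound 2 (1.14 log units; beyond the scatter) but involves a different group, so it says little here. For compound 4 the estimated step is a 1.1-fold higher number from compound 3 to compound 4 (0.04 log units; within the scatter) which means no expected move beyond the scatter. The estimate for compound 4 is an expected 1700 nM in a range from 550 nM to 5000 nM until a measurement is available.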

Compound 4, concentration for 50% growth inhibition: 2000 nM
Beside the measured number, compound 4's estimate is 1.2-fold (0.07 log units) below it; low and high end bracket the measured number.
By their numbers in this assay, from the lowest: compound 2; then compounds 3, 1 and 4 (each within the scatter of the next).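

In this assay, fluoro in place of hydroxy gives a 1.3-fold higher number from compound 3 to compound 4 (0.11 log units; within the scatter), and fluoro in place of hydrogen gives a 1.1-fold higher number from compound 1 to compound 4 (0.05 log units; within the scatter). Hydrogen, hydroxy and fluoro therefore read alike at this aromatic carbon, ortho to a methoxy group, even though the hydroxy that leaves counts a hydrogen-bond donor and a hydrogen-bond acceptor and the fluoro that enters counts neither. No measurement at hand offers a reason for this flat picture.

The compounds shown leave open whether an amine, a carboxylic acid or a longer chain at this carbon would move the number beyond the scatter. They also leave open whether fluoro here would read the same on the core of compound 2, where dimethylamino in place of methoxy gave a 14-fold lower number from compound 1 to compound 2 (1.14 log units; beyond the scatter).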